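The compounds below may be only part of what the source reports. "The series", "measured", "known", "first", "only" and "open" are said of these compounds alone.

Notes on the series. The shared core carries a 3-fluorophenyl in compound 1, `Fc1cccc(-c2nnc3sc(CCc4ccccc4)nn23)c1`, and a 2-methylfuran-3-yl in compound 2, `Cc1occc1-c1nnc2sc(CCc3ccccc3)nn12`. In an assay for inhibition of histone-lysine N-methyltransferase, H3 lysine-79 specific (Homo sapiens), read by scintillation counting, with stated times of 15 min and 60 min, tested at 100 uM, in the presence of a further agent that is not named here (on this read-out higher numbers stand for a stronger effect at the one concentration tested and lower numbers for a weaker effect), compound 1 gives 50%, and in this assay compound 2 gives 27%. Among the compounds with values here, the one measured step is a number 23 percentage points lower from compound 1 to compound 2 (beyond the scatter), so compound 2 stands lowest of the two numbers measured so far, with compound 1 as its only neighbour, a step beyond the scatter above it.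

Compound 3, `Cc1occc1-c1nnc2sc(Cc3ccccc3)nn12`, keeps the 2-methylfuran-3-yl of compound 2 and differs from it at the other end of the core: phenyl in place of benzyl on a saturated chain carbon bound to an aromatic carbon. Within the data shown here, no measured step touches this part of the molecule; the single step in hand concerns the aromatic substituent on the core and gives no guidance on shortening the benzyl to phenyl. With nothing to lean on, the estimate for compound 3 in this assay is kept close to the number of compound 2, with a wide range reflecting the absence of evidence. The expected step of no change at the digits printed from compound 2 to compound 3 (within the scatter) is therefore none beyond the scatter. Compound 3 is estimated at 27% in this assay, within a range from 5% to 50%.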

Compound 3, a percentage reported as inhibition, at one concentration (the size of the read-out at that concentration, not a potency): 24%
Compound 3: middle estimate off by 3 percentage points, on the high side; low and high end bracket the measured number.
By their numbers in this assay, from the lowest: compounds 3 and 2 (each within the scatter of the next); then compound 1.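

Within the data shown here, with the 2-methylfuran-3-yl held fixed, phenyl in place of benzyl on a saturated chain carbon bound to an aromatic carbon gives a number 3 percentage points lower from compound 2 to compound 3 (within the scatter) in this assay for the first look at this end of the molecule. Among these compounds, at this position, then, the read-out does not tell the two groups apart, whereas the one step beyond the scatter remains that on the other end of the core, a number 23 percentage points lower from compound 1 to compound 2 (beyond the scatter) and with 2-methylfuran-3-yl in place of 3-fluorophenyl on an aromatic carbon. No independent evidence bears on this result or accounts for it.

The compounds shown leave open whether phenyl and benzyl would also stay within the scatter of each other with a 3-fluorophenyl on the core, since the comparison stands on the 2-methylfuran-3-yl alone. They also leave open how this position responds to groups of another kind, such as a longer chain, an amine or a carboxylic acid in place of the phenyl, and what any of these compounds would show at concentrations other than the single one tested.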